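Thiophen-2-yl for naphthalen-2-yl on the sulfonyl sulfur

The source may report more compounds than this note shows. Statements on the series, on what has been measured and on what is new or still open speak of the compounds shown alone.

Measured so far in a functional assay on HCT-116 cells (Homo sapiens) for antiproliferative activity, read by WST assay, with a stated time of 72 h (a lower number here means a stronger inhibitor of growth, a higher number a weaker inhibitor of growth), with these values
- compound 1 `N#Cc1ccc(CN[C@H]2[C@@H]3CN(c4ncc(C(=O)NO)cn4)C[C@@H]32)cc1` at 270 nM
- compound 2 `O=C(NO)c1cnc(N2C[C@@H]3[C@H](C2)[C@H]3NS(=O)(=O)c2ccc3ccccc3c2)nc1` at 440 nM

Going by the values given here, compound 2 at 440 nM lies within the scatter of compound 1 at 270 nM in this assay and no measured pair shows a single change. Among the compounds with values here, compound 3 `O=C(NO)c1cnc(N2C[C@@H]3[C@H](C2)[C@H]3NS(=O)(=O)c2cccs2)nc1` carries thiophen-2-yl in place of naphthalen-2-yl on a sulfonyl sulfur and no measurement yet speaks to this change. No change beyond the scatter is expected in this assay with the estimated 1.4-fold higher number from compound 2 to compound 3 (0.13 log units; within the scatter) leaning to a higher number. Compound 3 is estimated at 600 nM with 200 nM to 1800 nM as the expected range.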

Compound 3, concentration for 50% growth inhibition: > 10000 nM
Compound 3: a limit, no number; the forecaster's own chance of this, stated with the estimate: 2%; middle value at least 16-fold (1.22 log units) from the limit.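

This position does not tolerate every aromatic group: in this assay, thiophen-2-yl in place of naphthalen-2-yl on a sulfonyl sulfur gives an at least 22-fold higher number from compound 2 to compound 3 (1.35 log units; beyond the scatter). For compound 3, the value > 10000 nM is a limit of the assay and not a number. The step therefore fixes only a bound, not a full size: the limit of > 10000 nM in this assay, at which 1 of the 3 values shown sits.

Going by these compounds, whether the step follows the smaller ring system or the ring sulfur remains open; a phenyl group on the sulfonyl sulfur would separate the two. Also open, on these data alone, is how a benzyl group or a longer alkyl chain there reads in this assay.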